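A few compounds are considered here, and "the series" means these few. Any claim that something is new, unique, unknown or untested is made for them only; others in the source may bear on it.

Measured compounds in a functional assay on L1210 cells (Mus musculus) for inhibition; on this read-out lower numbers stand for stronger inhibition and higher numbers for weaker inhibition:

Compound 1 `Nc1ccn(COCCO)c(=O)n1`: the result is a limit of the assay, > 1000 ug/mL.
Compound 2 `O=c1cc(O)ccn1COCCO`: likewise only a limit, > 1000 ug/mL.
Compound 3 `Nc1nc2c(nc(Cl)n2COCCO)c(=O)[nH]1`: again a limit, > 1000 ug/mL.

Compound 3 thus stands at the limit of > 1000 ug/mL in this assay, at which 3 of the 3 values shown sit; no number separates it from compound 1 or compound 2, and none of the three can be ranked against the others.

Compound 4 `Nc1nc2c(nc(N)n2COCCO)c(=O)[nH]1`, not yet measured, differs from compound 3 in one place: amino in place of chloro on an aromatic carbon. Among the compounds with values here, with no measured step and all three values at the limit, the size of this change in this assay cannot be read from the data; the expectation is no step beyond the scatter, the estimated change being a number no higher from compound 3 to compound 4 (the limit leaves the size open). Compound 4 is expected at 1000 ug/mL, within 250 ug/mL to 4000 ug/mL, most likely again reported only as a limit.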

Compound 4, concentration for 50% inhibition: 500 ug/mL
The estimate for compound 4 lay 2.0-fold (0.30 log units) above the measured number; low and high end bracket the measured number.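

Compound 4 is the only compound shown with a number rather than a limit in this assay, so amino on this aromatic carbon, between two ring nitrogen atoms, gives a reading the assay can quantify. Replacing chloro with amino here gives an at least 2.0-fold lower number from compound 3 to compound 4 (0.30 log units; that floor lies within the scatter). Only a floor can be given for this step because compound 3 sits at a limit: the limit of > 1000 ug/mL in this assay, at which 3 of the 4 values shown sit.

Going by these compounds, whether methylamino or bromo on this carbon would also give a number stays open. So does the reading with a longer chain in place of the (2-hydroxyethoxy)methyl group.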